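A few compounds are considered here, and "the series" means these few. Any claim that something is new, unique, unknown or untested is made for them only; others in the source may bear on it.

In a functional assay on HepG2 cells (Homo sapiens) for inhibition, read by MTT assay, with a stated time of 48 h (on this read-out higher numbers stand for weaker inhibition and lower numbers for stronger inhibition), compound 1 `CCOC(=O)C1=C(N/N=C(/Br)c2ccccc2)Nc2[nH]nc(C)c2C1c1ccc(N(C)C)cc1` reads 72000 nM while compound 2 `CCOC(=O)C(=NNC1=C(C(=O)OCC)C(c2ccc(N(C)C)cc2)c2c(C)n[nH]c2N1)C(=O)OCC` reads 80800 nM and compound 3 `CCOC(=O)C1=C(N/N=C(/C(=O)Br)c2ccc(Cl)cc2)Nc2[nH]nc(C)c2C1c1ccc(N(C)C)cc1` reads 50300 nM on the same read-out. Compound 3 therefore stands level with the other two, since its value lies within the scatter of both. Compound 4 `CCOC(=O)C1=C(N/N=C(/C(C)=O)C(=O)OCC)Nc2[nH]nc(C)c2C1c1ccc(N(C)C)cc1` has not yet been measured. Its difference from compound 3 is a group of 10 heavy atoms (6 carbon, 1 nitrogen, 3 oxygen; no ring) in place of a group of 12 heavy atoms (8 carbon, 1 nitrogen, 1 oxygen, 1 chlorine, 1 bromine; one six-membered aromatic ring of carbon only), on an amine nitrogen and the group that enters has no ring, as is also true of the corresponding group in compound 2. Three measured steps at this amine nitrogen bear on the question. The first is the step of a 1.1-fold higher number from compound 1 to compound 2 (0.05 log units; within the scatter) and the second is the step of a 1.4-fold lower number from compound 1 to compound 3 (0.16 log units; within the scatter) and both stay within the scatter. The closest in kind is the step of a 1.6-fold lower number from compound 2 to compound 3 (0.21 log units; within the scatter) which also stays within the scatter and puts a group with a ring in place of one without, the reverse of the exchange leading to compound 4. No step beyond the scatter is therefore expected in this assay and only a slight lean towards a higher number is anticipated. The expected size is a 1.3-fold higher number from compound 3 to compound 4 (0.11 log units; within the scatter) by this estimate. Compound 4 is estimated at 65000 nM with an expected range from 33000 nM to 130000 nM in this measurement.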

Compound 4, half-maximal inhibitory concentration: > 100000 nM
Compound 4 was reported as a limit (the forecaster's own chance of this, stated with the estimate: 10%); middle value at least 1.5-fold (0.18 log units) away from the limit.
By their numbers in this assay, from the lowest: compounds 3, 1 and 2 (each within the scatter of the next). At a limit, above all of these: compound 4.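

In this assay, among these compounds, compound 4 is the one compound of the four reported only as a limit and not as a number: the limit of > 100000 nM in this assay, at which 1 of the 4 values shown sits. On these data alone, its steps can therefore be read only as floors, an at least 1.9-fold higher number from compound 3 to compound 4 (0.29 log units; that floor lies within the scatter), an at least 1.2-fold higher number from compound 2 to compound 4 (0.09 log units; that floor lies within the scatter) and an at least 1.3-fold higher number from compound 1 to compound 4 (0.14 log units; that floor lies within the scatter), and the true size of each remains unknown. Among the compounds shown here, since every floor lies within the scatter, the group of 10 heavy atoms without a ring on this amine nitrogen gives a reading that the assay does not resolve as a number, yet no step at this position is established as beyond the scatter, whether that group replaces a group with a ring, as in compound 1 and compound 3, or the ring-free group of compound 2.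

The compounds shown leave open whether a free carboxylic acid in place of the ethyl ester in the entering group, or a plain phenyl ring carrying a methoxy group, would give a step beyond the scatter at this nitrogen. They also leave open whether any change away from this position, such as a primary amine in place of the dimethylamino group, would move the read-out.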